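The compounds below may be only part of what the source reports. "The series", "measured", "known", "first", "only" and "open" are said of these compounds alone.

Measured in a functional assay on ASPC1 cells (Homo sapiens) for inhibition, read by MTT assay, with a stated time of 96 h; on this read-out lower numbers stand for stronger inhibition of growth and higher numbers for weaker inhibition of growth:
- compound 1 `CC(C)C(=O)SCCCCCCNC(=O)c1cc(-c2ccncc2)n[nH]1`: 31700 nM
- compound 2 `C=CCOC(=O)SCCCCCCNC(=O)c1cc(-c2ccncc2)n[nH]1`: 27500 nM
- compound 3 `CCCC(=O)SCCCCCCNC(=O)c1cc(-c2ccncc2)n[nH]1`: 28100 nM

Compound 3, at 28100 nM, cannot be separated from the other two compounds, since all three values lie within the scatter of one another. The next compound is compound 4 `CC(=O)SCCCCCCNC(=O)c1cc(-c2ccncc2)n[nH]1`, which differs from compound 3 as follows: hydrogen in place of ethyl on a saturated chain carbon bound to a carbonyl carbon. This is hydrogen in place of ethyl on a saturated chain carbon bound to a carbonyl carbon, so propylcarbonyl becomes acetyl.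

Three measured steps change the group on that carbonyl carbon: a 1.1-fold lower number from compound 1 to compound 3 (0.05 log units; within the scatter), a 1.2-fold lower number from compound 1 to compound 2 (0.06 log units; within the scatter) and a 1.0-fold higher number from compound 2 to compound 3 (0.01 log units; within the scatter). All three stay within the scatter in this assay. Within the data shown here, none of the measured compounds carries the acetyl group, so this change itself is untested. On these steps, no shift beyond the scatter is expected, and no direction can be favoured. The expected step is a 1.0-fold lower number from compound 3 to compound 4 (0.00 log units; within the scatter). For compound 4 the estimated value is 28000 nM, with an expected range of 16000 nM to 48000 nM.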

Compound 4, concentration for 50% growth inhibition: > 50000 nM
Compound 4: only a limit was reported; the forecaster's own chance of this, stated with the estimate: 5%; middle value at least 1.7-fold (0.25 log units) from the limit.
By their numbers in this assay, from the lowest: compounds 2, 3 and 1 (each within the scatter of the next). At a limit, above all of these: compound 4.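

In this assay compound 4 gives > 50000 nM, which is a limit of the assay and not a number: the limit of > 50000 nM in this assay, at which 1 of the 4 values shown sits.

Acetyl is thus the first group on this carbonyl carbon without a numerical value, but the steps to it give only floors: an at least 1.7-fold higher number from compound 3 to compound 4 (0.25 log units; that floor lies within the scatter), an at least 1.8-fold higher number from compound 2 to compound 4 (0.25 log units; that floor lies within the scatter) and an at least 1.5-fold higher number from compound 1 to compound 4 (0.19 log units; that floor lies within the scatter). The earlier flat picture, in which propyl, isopropyl and allyloxy could not be told apart, therefore may not extend to methyl on the carbonyl carbon, but no loss of growth inhibition beyond the scatter is established.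

As far as these compounds go, whether compound 4 truly separates from compound 3 remains open. Also open, from the compounds shown here alone, is how a longer chain such as hexyl, or an amine, would read on that carbonyl carbon.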